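A few compounds are considered here, and "the series" means these few. Any claim that something is new, unique, unknown or untested is made for them only; others in the source may bear on it.

Compound 1 `CCCCCCNC(=O)c1[nH]cnc1C(=O)Nc1ccc(Cl)c(Cl)c1` gives 14600 nM in a functional assay on HL-60 cells (Homo sapiens), with a stated time of 2 days; on this read-out higher numbers stand for weaker inhibition and lower numbers for stronger inhibition. Compound 2 `C[C@H](NC(=O)c1[nH]cnc1C(=O)Nc1ccc(Cl)c(Cl)c1)c1ccccc1` gives 9200 nM. Compound 3 `COC(=O)[C@@H](NC(=O)c1[nH]cnc1C(=O)Nc1ccc(Cl)c(Cl)c1)C(C)C` gives only a limit of this assay, > 62500 nM, sitting at the limit of > 62500 nM in this assay, at which 1 of the 3 values shown sits. It therefore stands as the weakest of the three, since an at least 4.2-fold higher number from compound 1 to compound 3 (0.63 log units; beyond the scatter) and an at least 6.7-fold higher number from compound 2 to compound 3 (0.83 log units; beyond the scatter) both lie beyond the scatter. Compound 4 `CCCN(CCC)C(=O)c1[nH]cnc1C(=O)Nc1ccc(Cl)c(Cl)c1` is not yet measured and differs from compound 3 by dipropylamino in place of (1-(methoxycarbonyl)-2-methylpropyl)amino on a carbonyl carbon. Among the measured compounds shown here, the steps that bear on this change are those into compound 3, where hexyl and 1-phenylethyl on the amide nitrogen gave lower numbers than 1-(methoxycarbonyl)-2-methylpropyl. Because an at least 6.7-fold higher number from compound 2 to compound 3 (0.83 log units; beyond the scatter) runs toward the very group that compound 4 drops, the step is expected to run toward a lower number, about an at least 3.1-fold lower number from compound 3 to compound 4 (0.49 log units; beyond the scatter). Compound 4 is thus estimated at 20000 nM, ranging from 7000 nM to 62500 nM.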

Compound 4, half-maximal inhibitory concentration: 379000 nM
Compound 4: the middle estimate sits 19-fold (1.28 log units) below what was measured, outside the stated range (above it).
By their numbers in this assay, from the lowest: compounds 2 and 1 (each within the scatter of the next); then compound 4.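

In this assay, dipropylamino on a carbonyl carbon gives a 41-fold higher number from compound 2 to compound 4 (1.61 log units; beyond the scatter) and a 26-fold higher number from compound 1 to compound 4 (1.41 log units; beyond the scatter). Of the groups in this place, only dipropylamino carries no hydrogen-bond donor, and this change goes with a large rise in the number. Compound 3, which keeps a donor, gives only a limit, > 62500 nM, so its step to compound 4 cannot be read. Left open is whether propylamino, which keeps the amide hydrogen, would read like compound 1 or compound 2. As far as these compounds go, it is equally open where a ring amine such as piperidine would fall.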